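Chloropyridinyl Amide Measured Against the Cyanophenyl Benchmark

The source may report more compounds than this note shows. Statements on the series, on what has been measured and on what is new or still open speak of the compounds shown alone.

Going by the values given here, compound 3 `CC(C)c1sc(N2CCN(C)CC2)nc1C(=O)Nc1ccccc1C#N` is the only member of this small set that returns a number in an ADME assay on HepG2 cells (Homo sapiens) for inhibition; a lower number here means a stronger inhibitor, a higher number a weaker inhibitor: compound 3 gives 32000 nM. Compound 1 `CC(C)c1sc(N2CCN(C)CC2)nc1C(=O)Nc1ccc(F)cc1Cl` reaches only a limit of the assay, as in this assay compound 1 gives > 100000 nM. Compound 2 `CC(C)c1sc(N2CCN(C)CC2)nc1C(=O)Nc1ccccc1Cl` likewise reaches only a limit, as in this assay compound 2 gives > 100000 nM. Compound 4 `CC(C)c1sc(N2CCN(C)CC2)nc1C(=O)Nc1cccnc1Cl` differs from compound 3 by 2-chloropyridin-3-yl in place of 2-cyanophenyl on an amide-type nitrogen. Among the compounds with values here, the steps that bear on this change are an at least 3.1-fold lower number from compound 2 to compound 3 (0.49 log units; beyond the scatter) and an at least 3.1-fold lower number from compound 1 to compound 3 (0.49 log units; beyond the scatter), both moving from chloro to cyano. Returning to chloro, now within the 2-chloropyridin-3-yl group, is therefore expected to raise the number, and compound 4 is expected to shift by a 2.5-fold higher number from compound 3 to compound 4 (0.40 log units; beyond the scatter). Compound 4 is estimated at 80000 nM, between 30000 nM and 300000 nM, with a real chance that only a limit is reported.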

Compound 4, half-maximal inhibitory concentration: > 100000 nM
Compound 4 gave a limit, no number; the forecaster's own chance of this, stated with the estimate: 55%; at least 1.2-fold (0.09 log units) between middle value and limit.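

In this assay, the change to 2-chloropyridin-3-yl on the amide-type nitrogen gives an at least 3.1-fold higher number from compound 3 to compound 4 (0.49 log units; beyond the scatter). Going by these compounds alone, a chlorine-bearing ring with a hetero atom therefore joins the chlorine-bearing phenyl groups, and 2-cyanophenyl remains the only group here that yields a number. The steps from compound 1 and from compound 2 to compound 4 cannot be read, for all three compounds stand at the same point: the limit of > 100000 nM in this assay, at which 3 of the 4 values shown sit. As far as these compounds go, whether the ring hetero atom changes anything relative to 2-chlorophenyl stays open. So does whether 2-cyanopyridin-3-yl or 2-methoxyphenyl on that nitrogen would give a number.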